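Triazole-linked series: weak antiproliferative activity so far

The source may report more compounds than this note shows. Statements on the series, on what has been measured and on what is new or still open speak of the compounds shown alone.

Across the three measured members, activity in a functional assay on SW-620 cells (Homo sapiens) for antiproliferative activity, read by MTT assay, with a stated time of 72 h (on this read-out lower numbers stand for stronger inhibition and higher numbers for weaker inhibition), is weak throughout. Compound 1 `O=C1O[C@H]([C@@H](O)Cn2cc(-c3cc(C(F)(F)F)cc(C(F)(F)F)c3)nn2)C(OCc2ccccc2)=C1OCc1ccccc1` gives 49200 nM in this assay. Compound 2 `O=C1O[C@H]([C@@H](O)Cn2cc(-c3cccc(O)c3)nn2)C(OCc2ccccc2)=C1OCc1ccccc1` reaches only the limit of this assay, > 100000 nM. Compound 3 `CCCCCc1ccc(-c2cn(C/C=C3\OC(=O)C(OCc4ccccc4)=C3OCc3ccccc3)nn2)cc1` likewise sits at the limit of this assay, > 100000 nM. Compound 2 therefore stands at the top of the numbers shown, on (the limit of > 100000 nM in this assay, at which 2 of the 3 values shown sit), with no number of its own. Compound 4 `O=C1O[C@H]([C@@H](O)Cn2cc(CNS(=O)(=O)c3ccc(Cl)cc3)nn2)C(OCc2ccccc2)=C1OCc1ccccc1` differs from compound 2 by (((4-chlorophenyl)sulfonyl)amino)methyl in place of 3-hydroxyphenyl on an aromatic carbon. For the measured compounds named here, no measured step of this kind exists here, so no direction beyond the scatter is expected, and a result near the limit remains likely. For compound 4 in this assay the expected step is an at least 1.2-fold lower number from compound 2 to compound 4 (0.09 log units; that floor lies within the scatter). Compound 4 is estimated at 80000 nM, between 30000 nM and 200000 nM.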

Compound 4, half-maximal inhibitory concentration: 18000 nM
For compound 4 the middle estimate is 4.4-fold (0.65 log units) above the measured one; the whole stated range lies above it.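

For the compounds shown here, at this aromatic carbon of the five-membered ring, exchanging 3-hydroxyphenyl for (((4-chlorophenyl)sulfonyl)amino)methyl gives the first measured step, an at least 5.5-fold lower number from compound 2 to compound 4 (0.74 log units; beyond the scatter) in this assay. The position therefore responds to change beyond the scatter, and the aryl group need not sit directly on the ring. The size of the step is only a floor, since the value for compound 2 is a limit: the limit of > 100000 nM in this assay, at which 2 of the 4 values shown sit.

Which part of the new group carries the step remains open: the sulfonamide, the methyl spacer or the chlorine. So does the response in this assay to a simple amine or a carboxylic acid at this carbon.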